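Meta-chloro for para-fluoro on the benzyl ether

This account rests on a few compounds, and the source may have more. Where it says the series, first, only, none or still open, it means among the compounds named here.

Compound 1 `Cc1cc(C(=O)O)nn1Cc1cc(Br)ccc1OCc1ccc(F)cc1` gives 7.41 nM in an assay on CHO-K1 cells for displacement of a labelled ligand from prostaglandin E2 receptor EP1 subtype (Homo sapiens) (a higher number here means a weaker inhibitor, a lower number a stronger inhibitor), the lowest of the two numbers measured; its nearest neighbour, compound 2 `Cc1cc(C(=O)O)nn1Cc1cc(Br)ccc1OCc1ccc(C(F)(F)F)cc1`, gives 35.5 nM. For the measured compounds named here, the one measured step, a 4.8-fold higher number from compound 1 to compound 2 (0.68 log units; beyond the scatter), swaps a group on the same benzyl ring. Compound 3 `Cc1cc(C(=O)O)nn1Cc1cc(Br)ccc1OCc1cccc(Cl)c1` differs from compound 1 by 3-chlorophenyl in place of 4-fluorophenyl on a saturated chain carbon bound to an oxygen on an aromatic ring. Going by the values given here, no measured step tests a chloro at that position, so the trifluoromethyl step is only a loose guide to a change in the weakening direction. For compound 3 a modest step of a 2.0-fold higher number from compound 1 to compound 3 (0.31 log units; beyond the scatter) is expected, giving an estimate of 15 nM, within 5 nM to 50 nM.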

Compound 3, half-maximal inhibitory concentration: 115 nM
For compound 3 the middle estimate is 7.7-fold (0.88 log units) below the measured one, and the stated range ends below it.
By their numbers in this assay, from the lowest: compound 1; then compound 2; then compound 3.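

On the benzyl ether of the shared core, the move to 3-chlorophenyl gives a 16-fold higher number from compound 1 to compound 3 (1.19 log units; beyond the scatter) in this assay, a larger step than a 4.8-fold higher number from compound 1 to compound 2 (0.68 log units; beyond the scatter) seen with trifluoromethyl. For the compounds shown here, this position therefore tolerates changes less well than the one earlier step suggested, and of the three compounds, the 4-fluorophenyl of compound 1 gives the lowest number. No measurement here explains this difference. The step changes both the halogen and the ring position at once, so the data cannot separate the two. A 4-chlorophenyl or 3-fluorophenyl group would address that question.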